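Pyrazoline series: swapping the aryl group on the saturated carbon

The source may report more compounds than this note shows. Statements on the series, on what has been measured and on what is new or still open speak of the compounds shown alone.

Two members of the series have numbers in a functional assay on the whole organism (strain albino) for inhibition, with Rattus norvegicus as the target, read by paw edema, with stated times of 30 min and 2 h, at a dose of 100 mg/kg by the oral route; a lower number here means less inhibition, a higher number more inhibition at the dose given (going by the name of the read-out). Compound 1 `COc1ccc(C2=NN(C(=O)CO[N+](=O)[O-])C(c3c(Cl)cccc3Cl)C2)cc1OC` gives 49% in this assay. Compound 2 `COc1ccc(C2CC(c3ccc(OC)c(OC)c3)=NN2C(=O)C(C)Br)c(OC)c1` gives 63% in this assay, the higher of the two numbers, and the gap to compound 1 lies beyond the scatter. Compound 1 and compound 2 differ in more than one place, so their two numbers alone cannot be tied to a single change.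

Compound 3 `COc1ccc(C2=NN(C(=O)C(C)Br)C(c3c(Cl)cccc3Cl)C2)cc1OC` is not yet measured. It differs from compound 2 in one place: 2,6-dichlorophenyl in place of 2,4-dimethoxyphenyl on a saturated ring carbon. Among the compounds with values here, compound 1 carries the same entering group on the same carbon but a different acyl group, so no measured step isolates this change. On these numbers, a modest drop is expected from compound 2 to compound 3, of the size a number 8 percentage points lower from compound 2 to compound 3 (within the scatter), though a step within the scatter is also plausible. Compound 3 is estimated at 55% in this assay, with a range from 40% to 70%.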

Compound 3, a percentage reported as inhibition, in the whole organism at one dose (the size of the read-out at that dose, not a potency): 56%
Compound 3: the middle estimate sits 1 percentage points below what was measured, within the range that was stated.
By their numbers in this assay, from the lowest: compounds 1, 3 and 2 (each within the scatter of the next, the first and the last beyond it).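

In this assay, 2,6-dichlorophenyl in place of 2,4-dimethoxyphenyl on the saturated ring carbon gives a number 7 percentage points lower from compound 2 to compound 3 (within the scatter), so at this dose the two aryl groups cannot be told apart at this position. With 2,6-dichlorophenyl held fixed, the acyl change of 1-bromoethyl in place of (nitrooxy)methyl on the carbonyl carbon gives a number 7 percentage points higher from compound 1 to compound 3 (within the scatter), so neither single change read here is beyond the scatter, although compound 1 and compound 2 are further apart. Nothing available explains either step.

Open, going by these compounds, is how a cyclohexyl group or a pyridine ring on this saturated ring carbon would read. Also open, on these data alone, is whether an amine or a carboxylic acid in place of the bromine on the acyl chain would move the number beyond the scatter.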